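The source may hold more compounds than are shown below. What is called first, only, known or untested is meant among the compounds shown, and "the series" means these compounds.

Compound 3, `COc1ccc(-c2sc(N)c(C(=O)c3ccc(Cl)c(Cl)c3)c2CC(C)(C)C)cc1`, is one of three compounds read in an assay on CHO cells for displacement of a labelled ligand from adenosine receptor A3 (Homo sapiens), read by scintillation counting, tested at 10 uM; a lower number here means less inhibition, a higher number more inhibition at the concentration tested (going by the name of the read-out). Its companions are compound 1, `CC(C)(C)Cc1c(Br)sc(N)c1C(=O)c1cccc(C(F)(F)F)c1`, and compound 2, `COc1ccc(-c2sc(N)c(C(=O)c3ccc(Cl)cc3)c2CC(C)(C)C)cc1`. In this assay compound 1 gives 4%, compound 2 gives 2% and compound 3 gives 1%; the three numbers all lie within the scatter of one another, so compound 3 stands beside the other two rather than apart from them. Going by the values given here, the single one-place step that has been measured, a number 1 percentage points lower from compound 2 to compound 3 (within the scatter), came from chloro in place of hydrogen on an aromatic carbon and stayed within the scatter.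

Compound 4, `COc1ccc(-c2sc(N)c(C(=O)c3cccc(C(F)(F)F)c3)c2CC(C)(C)C)cc1`, differs from compound 3 in one place: 3-(trifluoromethyl)phenyl in place of 3,4-dichlorophenyl on a carbonyl carbon. The measured step on the same benzoyl part, a number 1 percentage points lower from compound 2 to compound 3 (within the scatter), bears on this change and was within the scatter. Compound 1, which carries the same 3-(trifluoromethyl)phenyl on a different core, also gives a small number, 4%. Compound 4 is therefore expected to stay within the scatter of compound 3, a step of a number 2 percentage points higher from compound 3 to compound 4 (within the scatter). The estimate for compound 4 in this assay is 3%, ranging from -5% to 12%.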

Compound 4, a percentage reported as inhibition, at one concentration (the size of the read-out at that concentration, not a potency): 1%
Beside the measured number, compound 4's estimate is 2 percentage points above it, and the stated range covers the measured number.
By their numbers in this assay, from the lowest: compounds 3, 4, 2 and 1 (each within the scatter of the next).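

With the group on the carbonyl carbon changed, 3-(trifluoromethyl)phenyl in place of 3,4-dichlorophenyl gives no change at the digits printed from compound 3 to compound 4 (within the scatter) in this assay and 3-(trifluoromethyl)phenyl in place of 4-chlorophenyl gives a number 1 percentage points lower from compound 2 to compound 4 (within the scatter) on the same core, so three aryl groups at this place now read alike. The other one-place change, 4-methoxyphenyl in place of bromo on an aromatic carbon, gives a number 3 percentage points lower from compound 1 to compound 4 (within the scatter) and shows that a second site on the core also yields no step beyond the scatter with 3-(trifluoromethyl)phenyl held fixed. No evidence on this result is available to explain these readings.

From the compounds shown here alone, all four compounds carry aryl groups without a charge on the carbonyl carbon, so it stays open whether an amine or a carboxylic acid on that ring would move the number in this assay beyond the scatter. Going by these compounds, it also stays open whether a longer chain in place of bromo or 4-methoxyphenyl would do so.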